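Azido in place of hydrogen on a furanose-type uracil acid

The compounds below may be only part of what the source reports. "The series", "measured", "known", "first", "only" and "open" are said of these compounds alone.

Measured so far:
Compound 1 `Cc1cn([C@H]2C=C[C@@H](C(=O)O)O2)c(=O)[nH]c1=O` — > 250 ug/mL
Compound 2 `O=C(O)[C@@H]1CC[C@H](n2ccc(=O)[nH]c2=O)O1` — > 250 ug/mL

Both values in an ADME assay on Huh-7 cells (Homo sapiens) for cytotoxicity, read by XTT assay, with a stated time of 2 days (on this read-out lower numbers stand for higher toxicity in this test and higher numbers for lower toxicity in this test), are limits of the assay rather than numbers. Compound 1 reaches only a limit in this assay, > 250 ug/mL. Compound 2 likewise shows only a limit, > 250 ug/mL, so where it stands among the values shown is fixed only by the limit of > 250 ug/mL in this assay, at which 2 of the 2 values shown sit. Compound 3 `[N-]=[N+]=N[C@H]1C[C@H](n2ccc(=O)[nH]c2=O)O[C@@H]1C(=O)O` differs from compound 2 in one place: azido in place of hydrogen on a saturated ring carbon. Within the data shown here, no step between measured compounds is available to size this change, and the two values seen say only that neither compound was toxic within the tested range. The step from compound 2 to compound 3 is therefore expected to be none beyond the scatter, and compound 3 is expected to sit again at the limit, a number no higher from compound 2 to compound 3 (the limit leaves the size open). Compound 3 is estimated at 250 ug/mL, with a range from 100 ug/mL to 500 ug/mL.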

Compound 3, half-maximal cytotoxic concentration: > 250 ug/mL
Compound 3 was reported as a limit; the forecaster's own chance of this, stated with the estimate: 80%; the middle value sits exactly at the limit.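

In this assay compound 3 gives > 250 ug/mL, which is a limit of the assay. Among these compounds, compound 2 also stands at a limit, so no step from compound 2 to compound 3 can be read. What azido in place of hydrogen on a saturated ring carbon does to cytotoxicity stays open: the limit of > 250 ug/mL in this assay, at which 3 of the 3 values shown sit.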